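The source may report more compounds than this note shows. Statements on the series, on what has been measured and on what is new or still open speak of the compounds shown alone.

Working notes on the series. The shared core carries a carboxamide to an aniline bearing a single substituent in the position named for each compound. Compound 1 `COc1cc(OC)c2c(=O)cc(C(=O)Nc3ccc(Oc4ccc([N+](=O)[O-])cc4)cc3)[nH]c2c1` has no result in a functional assay on UoC-B1 cells (Homo sapiens) for antiproliferative activity, with a stated time of 72 h; on this read-out lower numbers stand for an effect already at smaller amounts and higher numbers for an effect only at larger amounts of compound: for compound 1 the entry reads "not determined" (no result reported). Compound 2 `COc1cc(OC)c2c(=O)cc(C(=O)Nc3ccc(Oc4ccc(F)cc4)cc3)[nH]c2c1` returns only a limit in this assay; compound 2 stands at > 50000 nM, which is the limit of > 50000 nM in this assay, at which 1 of the 2 values shown sits, and not a number. On the numbers shown, compound 2 therefore sits at the limit and nothing else is placed.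

Compound 3 `COc1cc(OC)c2c(=O)cc(C(=O)Nc3ccc(-n4cccc4)cc3)[nH]c2c1` is the next member to be measured. Its change from compound 2 is 1H-pyrrol-1-yl in place of 4-fluorophenoxy on an aromatic carbon. Among the compounds with values here, no step between measured compounds is available to size this change, so no direction beyond the scatter is taken; the step expected from compound 2 to compound 3 is a number no higher from compound 2 to compound 3 (the limit leaves the size open). For compound 3 the estimate in this assay is 50000 nM, with a range from 10000 nM to 250000 nM, and a limit is again thought likely.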

Compound 3, half-maximal effective concentration: 51800 nM
Compound 3: the middle estimate sits 1.0-fold (0.02 log units) below what was measured, within the range that was stated.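

Within the data shown here, no step from compound 2 to compound 3 can be read in this assay, because compound 2 is held only by a limit: the limit of > 50000 nM in this assay, at which 1 of the 3 values shown sits.
The compounds shown leave open whether 1H-pyrrol-1-yl in place of 4-fluorophenoxy shifts this read-out at all, and in which direction.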